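Benzyl in place of dihydroxypropyl on the shared core

The source may report more compounds than this note shows. Statements on the series, on what has been measured and on what is new or still open speak of the compounds shown alone.

Measured compounds:
- compound 1 `CCCc1nc(C)c2c(C)nn(CC(O)CO)c(=O)n12`: > 48000 nM
- compound 2 `CCCc1nc(C)c2cnn(CC(O)CO)c(=O)n12`: > 48000 nM
- compound 3 `O/C(=C/c1nncc2cncn12)c1ccccc1`: 38000 nM

In a functional assay for inhibition, with Homo sapiens as the target (on this read-out lower numbers stand for stronger inhibition and higher numbers for weaker inhibition), compound 1 gives > 48000 nM, which is a limit of the assay and not a number. Compound 2 likewise gives only a limit, > 48000 nM. Compound 3, built on a different core, gives 38000 nM. Compound 1 thus stands at the limit of > 48000 nM in this assay, at which 2 of the 3 values shown sit, so its true value is not known.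

Among the measured compounds shown here, the only measured step, a step that the two limits leave unreadable from compound 1 to compound 2, concerns a hydrogen in place of a methyl on an aromatic carbon and cannot be read between two limits. It does not touch the change to compound 4 `CCCc1nc(C)c2c(C)nn(Cc3ccccc3)c(=O)n12`, which is phenyl in place of 1,2-dihydroxyethyl on a saturated chain carbon bound to an aromatic nitrogen. For the measured compounds named here, no measured step therefore bears on this change, and no direction can be expected from the data beyond the scatter.

Compound 4 is estimated at 40000 nM, with a range from 8000 nM to 150000 nM, meaning an expected step of an at least 1.2-fold lower number from compound 1 to compound 4 (0.07 log units; that floor lies within the scatter), with a fair chance that this assay again reports only a limit.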

Compound 4, half-maximal inhibitory concentration: > 48000 nM
Compound 4: a limit, no number; the forecaster's own chance of this, stated with the estimate: 60%; middle value at least 1.2-fold (0.07 log units) away from the limit.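

In this assay, among the compounds shown here, compound 4 gives > 48000 nM, which is a limit of the assay and not a number, so no step from compound 1, itself known only as a limit, can be read. The compounds shown leave open whether 2,3-dihydroxypropyl or benzyl on the shared core gives the lower number: the limit of > 48000 nM in this assay, at which 3 of the 4 values shown sit.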